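The compounds below may be only part of what the source reports. "The series", "measured", "known", "first", "only" and "open" are said of these compounds alone.

Compound 2, `CN(C)c1cccc(Oc2ccc3c(NCCCNCc4ccco4)ccnc3c2)c1`, and compound 1, `COc1ccc(F)cc1CNCCCNc1ccnc2cc(Oc3ccc(F)cc3)ccc12`, were both examined in a physicochemical assay for acid dissociation. In this assay compound 1 gives 9.28, and in this assay compound 2 gives 9.28, so compound 2 stands level with compound 1 at the digits shown, with no change beyond the scatter. The unmeasured compound 3, `COc1ccc(F)cc1CNCCCNc1ccnc2cc(Oc3cccc(N(C)C)c3)ccc12`, differs from compound 2 in one place: 5-fluoro-2-methoxyphenyl in place of furan-2-yl on a saturated chain carbon bound to an amine nitrogen. Among the measured compounds shown here, no step between two measured compounds isolates this change. Still, the values of compound 1 and compound 2 show that the group on this saturated chain carbon can be swapped while the value stays put, because compound 1 gives 9.28 with the entering 5-fluoro-2-methoxybenzyl group already in place. The step from compound 2 to compound 3, a number 0.02 log units higher from compound 2 to compound 3 (within the scatter), is therefore expected to be none beyond the scatter. Compound 3 is estimated to give 9.3, with a range from 9 to 9.6.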

Compound 3, acid dissociation constant: 9.28
For compound 3 the middle estimate is 0.02 log units above the measured one, and the stated range covers the measured number.
By their numbers in this assay, from the lowest: compounds 1, 2 and 3 (each within the scatter of the next).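

In this assay, 5-fluoro-2-methoxyphenyl in place of furan-2-yl on a saturated chain carbon bound to an amine nitrogen gives no change at the digits printed from compound 2 to compound 3 (within the scatter), so this swap can now be read on its own. Likewise, 3-(dimethylamino)phenyl in place of 4-fluorophenyl on an oxygen on an aromatic ring gives no change at the digits printed from compound 1 to compound 3 (within the scatter), which shows that neither change alone moves the number beyond the scatter, so the matching values seen earlier do not hide two larger, opposing steps. Nothing among the data offers an explanation for this flat result.

The compounds shown all carry an aromatic ring at both places. As far as these compounds go, whether a carboxylic acid or a piperidine on the saturated chain carbon, or a longer chain on the amine nitrogen, would shift the number remains open.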